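The source may hold more compounds than are shown below. What is called first, only, known or untested is meant among the compounds shown, and "the series" means these compounds.

Series notes. Going by the values given here, in a functional assay on SiHa cells (Homo sapiens) for cytotoxicity, read by MTT assay, with a stated time of 48 h (on this read-out lower numbers stand for stronger inhibition and higher numbers for weaker inhibition), compound 2 `CCCCCCCCNC(=O)[C@@H](NC(=O)c1ccccc1)[C@@H](C)O` gives 112000 nM, which places it second highest of the three numbers measured so far. Compound 3 `CCCCCCCCNC(=O)[C@@H](NC(=O)c1ccco1)[C@@H](C)O` gives 124000 nM in this assay, and a 1.1-fold higher number from compound 2 to compound 3 (0.04 log units; within the scatter), so the two stand together. Among the compounds with values here, compound 1 `CCCCCCCCCCCCCCNC(=O)[C@@H](N)[C@@H](C)O` gives 11000 nM, a lower number than compound 2, but compound 1 differs from compound 2 in two places and no single step joins them. Compound 4 `CCCCCCCCCCCCCCNC(=O)[C@@H](NC(=O)c1ccccc1)[C@@H](C)O` differs from compound 2 by hexyl in place of hydrogen on a saturated chain carbon, eight bonds along the chain from an amide-type nitrogen. Within the data shown here, no measured step bears directly on this change; the only pointer is that compound 1, which also carries the longer chain, gives 11000 nM. On that basis a lower number in this assay is expected for compound 4, with the step of a 3.7-fold lower number from compound 2 to compound 4 (0.57 log units; beyond the scatter) estimated. The estimate for compound 4 is 30000 nM, within a range from 8000 nM to 110000 nM.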

Compound 4, half-maximal inhibitory concentration: > 200000 nM
Compound 4 gave a limit, no number (the forecaster's own chance of this, stated with the estimate: 5%); middle value at least 6.6-fold (0.82 log units) from the limit.
By their numbers in this assay, from the lowest: compound 1; then compounds 2 and 3 (each within the scatter of the next). At a limit, above all of these: compound 4.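

In this assay compound 4 gives > 200000 nM, a limit and not a number: the limit of > 200000 nM in this assay, at which 1 of the 4 values shown sits. Benzoyl in place of hydrogen on the amine nitrogen of the longer-chain compound gives a large step, an at least 18-fold higher number from compound 1 to compound 4 (1.25 log units; beyond the scatter), whereas the earlier step only exchanged phenyl for furan-2-yl on the carbonyl carbon. Hexyl on the chain of the benzoyl amide gives no lower number, an at least 1.7-fold higher number from compound 2 to compound 4 (0.25 log units; that floor lies within the scatter), and that floor stays within the scatter. Going by these compounds, the true size of that chain step remains open. So does the effect of an acetyl group or a smaller amine substituent on the amine nitrogen.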